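A few compounds are considered here, and "the series" means these few. Any claim that something is new, unique, unknown or untested is made for them only; others in the source may bear on it.

Working notes on the series. Among the compounds with values here, the shared core of compound 1 `COc1cccc(Nc2nccc(-c3ccc(C)o3)n2)c1` is kept throughout; in a functional assay for inhibition, with Homo sapiens as the target (on this read-out higher numbers stand for weaker inhibition and lower numbers for stronger inhibition), compound 1 gives 1500 nM, the lowest of the three numbers measured so far. Compound 3 `Cc1cccc(Nc2nccc(-c3ccc(C)o3)n2)c1` carries methyl in place of methoxy on an aromatic carbon and gives 2000 nM in this assay; the step of a 1.3-fold higher number from compound 1 to compound 3 (0.12 log units; within the scatter) is within the scatter, so the two stand together. Within the data shown here, compound 2 `Fc1cccc(F)c1Nc1nccc(-c2cccnc2)n1` differs from compound 1 in two places at once; in this assay compound 2 gives 21000 nM, a number far beyond the scatter from compound 1; with no single-point step between them, the two values only show that the change at both ends together costs inhibition.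

Compound 4 `COc1cccc(Nc2nccc(-c3ccncc3)n2)c1` is the next step from compound 1: pyridin-4-yl in place of 5-methylfuran-2-yl on an aromatic carbon. Among the measured compounds shown here, no measured step touches this position; the one single-point step known, from compound 1 to compound 3, sits on the aniline side and is silent here. For the measured compounds named here, the only hint is compound 2, where a six-membered ring with one nitrogen at this position accompanies the weakest inhibition of the set, though its aniline also differs. On this basis a moderate rise in the number is expected for compound 4 in this assay, a 2.7-fold higher number from compound 1 to compound 4 (0.43 log units; beyond the scatter), giving an estimate of 4000 nM with a range from 1200 nM to 15000 nM.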

Compound 4, half-maximal inhibitory concentration: 400 nM
Compound 4: the middle estimate sits 10-fold (1.00 log units) above what was measured, and the stated range ends above it.
By their numbers in this assay, from the lowest: compound 4; then compounds 1 and 3 (each within the scatter of the next); then compound 2.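

Within the data shown here, the aromatic carbon next to the ring nitrogen responds to change in this assay: the step to pyridin-4-yl gives a 3.8-fold lower number from compound 1 to compound 4 (0.57 log units; beyond the scatter), the first single-point step beyond the scatter, and it runs towards stronger inhibition. The heavy-atom count and the counts of donors and acceptors stay the same across this change, so those counts do not separate the two groups, while ring size, the hetero atom and the methyl on the furan all change at once and this single step cannot tell them apart. Nothing at hand bears on why the number falls at this position.

The compounds shown leave open which part of the change matters, since a plain phenyl ring, an unmethylated furan-2-yl and a pyridin-2-yl at this position would each separate ring size, hetero atom and methyl. Also open, going by these compounds, are whether the step holds with methyl in place of methoxy on the aromatic carbon of the other ring, and whether an amine or a carboxylic acid on the pyridine ring keeps the number this low.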